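The compounds below may be only part of what the source reports. "The series", "measured", "known", "first", "only" and "open" are said of these compounds alone.

Compound 1 `COc1ccc(Cc2nnc(NC(=O)/C(C#N)=C/c3ccccc3OS(=O)(=O)c3ccccc3[N+](=O)[O-])s2)cc1` gives 25%
Compound 2 `N#C/C(=C\c1ccccc1OS(=O)(=O)c1ccccc1[N+](=O)[O-])C(=O)Nc1nnc(Cc2cccc(F)c2)s1` gives 23%
Compound 3 `N#C/C(=C\c1ccccc1OS(=O)(=O)c1ccccc1[N+](=O)[O-])C(=O)Nc1nnc(Cc2ccc(Cl)cc2)s1` gives 19%

These values come from a functional assay on HL-60 cells (Homo sapiens) for inhibition, read by CCK-8 assay, with a stated time of 48 h, tested at 20 uM (a lower number here means less inhibition of growth, a higher number more inhibition of growth at the concentration tested), and compound 3 stands within the scatter of both other compounds. Compound 4 `Cc1ccc(Cc2nnc(NC(=O)/C(C#N)=C/c3ccccc3OS(=O)(=O)c3ccccc3[N+](=O)[O-])s2)cc1` differs from compound 3 by methyl in place of chloro on an aromatic carbon in one place: methyl in place of chloro on an aromatic carbon, para to a large group. Among the compounds with values here, three measured steps bear on this change, and all are small. Chloro in place of methoxy gave a number 6 percentage points lower from compound 1 to compound 3 (within the scatter) and the two swaps of the whole substituted phenyl gave a number 2 percentage points lower from compound 1 to compound 2 (within the scatter) and a number 4 percentage points lower from compound 2 to compound 3 (within the scatter) without leaving the scatter. The estimated result is a number 3 percentage points higher from compound 3 to compound 4 (within the scatter) in this assay and no step beyond the scatter is expected. Compound 4 is expected at 22% with an estimated range of 12% to 33% as its likely span.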

Compound 4, percent growth inhibition at one concentration: 33%
For compound 4 the middle estimate is 11 percentage points below the measured one; the measured number falls inside the stated range.
By their numbers in this assay, from the lowest: compounds 3, 2, 1 and 4 (each within the scatter of the next, the first and the last beyond it).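

In this assay the change of chloro to methyl gives a number 14 percentage points higher from compound 3 to compound 4 (beyond the scatter) and is the only step among these compounds that leaves the scatter, so this one-atom swap at the end of the benzyl group can matter. Compound 4 stays within the scatter of the other two, with a number 10 percentage points higher from compound 2 to compound 4 (within the scatter) and a number 8 percentage points higher from compound 1 to compound 4 (within the scatter) as its steps, so only compound 3 is set apart from it. Nothing given here explains this difference.

From the compounds shown here alone, whether ethyl, trifluoromethyl or an amine at this place would move the number further remains open.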